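Swapping the Five-Membered Ring on a Shared Core

The source may report more compounds than this note shows. Statements on the series, on what has been measured and on what is new or still open speak of the compounds shown alone.

Compound 1, `O=C(O)c1cc(-c2nccs2)ccc1O`: in a functional assay on the whole organism for inhibition, with Rattus norvegicus as the target, read by paw edema (a lower number here means that less compound is needed, a higher number that more compound is needed for the effect), compound 1 gives > 250 mg/kg, which is a limit of the assay and not a number.
Compound 2, `O=C(O)c1cc(-c2ncc[nH]2)ccc1O`: in this assay compound 2 gives 200 mg/kg.
Compound 3, `O=C(O)c1cc(-n2cccn2)ccc1O`: in this assay compound 3 gives 200 mg/kg.

The three measured compounds share one core and differ only in the five-membered aromatic ring attached to it. Compound 3 stands level with compound 2: no change at the digits printed from compound 2 to compound 3 (within the scatter). Toward compound 1 the steps read an at least 1.2-fold lower number from compound 1 to compound 2 (0.09 log units; that floor lies within the scatter) and an at least 1.2-fold lower number from compound 1 to compound 3 (0.09 log units; that floor lies within the scatter), and both are bounded by the limit of > 250 mg/kg in this assay, at which 1 of the 3 values shown sits, so their true size is not known.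

Among the compounds with values here, compound 4, `O=C(O)c1cc(-n2nccn2)ccc1O`, has not been measured. 2H-1,2,3-triazol-2-yl in place of 1H-pyrazol-1-yl on an aromatic carbon Among the measured steps, only the one from compound 2 to compound 3 concerns an exchange of one five-membered ring for another, and it showed no change within the scatter. The step from compound 3 to compound 4 in this assay is therefore expected to be no change at the digits printed from compound 3 to compound 4 (within the scatter), that is, nothing beyond the scatter. Compound 4 is estimated to give 200 mg/kg, with a likely range from 110 mg/kg to 400 mg/kg.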

Compound 4, dose for half-maximal effect: 150 mg/kg
Compound 4: the middle estimate sits 1.3-fold (0.12 log units) above what was measured; the range from low to high includes it.
By their numbers in this assay, from the lowest: compounds 4, 2 and 3 (each within the scatter of the next). At a limit, above all of these: compound 1.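

At this position, para to a hydroxy group and meta to a carboxy group, the 2H-1,2,3-triazol-2-yl ring brings 3 hetero atoms and 3 hydrogen-bond acceptors in place of 2 of each, yet this assay shows a 1.3-fold lower number from compound 3 to compound 4 (0.12 log units; within the scatter). Against the ring of compound 2, the reading is a 1.3-fold lower number from compound 2 to compound 4 (0.12 log units; within the scatter), so these three nitrogen-containing rings cannot be told apart here. As far as these compounds go, the comparison with the thiazole ring gives an at least 1.6-fold lower number from compound 1 to compound 4 (0.22 log units; that floor lies within the scatter), and its true size stays unknown: the limit of > 250 mg/kg in this assay, at which 1 of the 4 values shown sits.

From the compounds shown here alone, it remains open whether a larger group here, such as a pyridine ring or a five-membered ring carrying an amine or a methyl group, would move the number beyond the scatter. Also open, going by these compounds, is what a methoxy group in place of the hydroxy group would do.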